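The source may report more compounds than this note shows. Statements on the series, on what has been measured and on what is new or still open speak of the compounds shown alone.

Measured so far in a functional assay on BGC-823 cells (Homo sapiens) for cytotoxicity, read by MTT assay; a lower number here means a stronger inhibitor, a higher number a weaker inhibitor:
compound 1 `Cc1nc(Nc2ccccc2)sc1C(=O)/C=C/c1ccc(Cl)cc1` gives > 25000 nM, a limit of this assay and not a number.
compound 2 `Cc1ccccc1Nc1nc(C)c(C(=O)/C=C/c2ccc(Cl)cc2)s1` gives > 25000 nM, likewise a limit of this assay and not a number.

Compound 2 therefore stands at the limit, where both values shown sit (the limit of > 25000 nM in this assay, at which 2 of the 2 values shown sit). Going by the values given here, the only measured step, a step that the two limits leave unreadable from compound 1 to compound 2, joins two limits and its size cannot be read.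

Compound 3 `Cc1ccc(Nc2nc(C)c(C(=O)/C=C/c3ccc(Cl)cc3)s2)cc1` arises from compound 2 by the change (4-methylphenyl in place of 2-methylphenyl on a nitrogen on an aromatic ring). Among the compounds with values here, no readable step bears on this change, and the single step measured gives no size to carry over. Nothing in the numbers shown points to a move off the limit in either direction, so no step beyond the scatter is expected. Compound 3 is therefore expected to give an estimated 40000 nM in this assay, within 15000 nM to 120000 nM. The estimated step that the limit leaves unreadable from compound 2 to compound 3 is expected to be no more than the scatter, with the assay most likely again reporting only a limit.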

Compound 3, half-maximal inhibitory concentration: > 25000 nM
Compound 3: a limit, no number (the forecaster's own chance of this, stated with the estimate: 85%); the middle value lies beyond the limit too.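

In this assay the steps among compound 1, compound 2 and compound 3 cannot be read, as all three stand at a limit: the limit of > 25000 nM in this assay, at which 3 of the 3 values shown sit. The compounds shown leave open how far each lies beyond that limit, and whether the methyl or its place on the phenyl ring matters at all.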